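Swapping a substituted phenyl ring in a melanocortin receptor series

This account rests on a few compounds, and the source may have more. Where it says the series, first, only, none or still open, it means among the compounds named here.

Measured compounds:
- compound 1 `CC(C)[C@H](NC(=O)CCN(C)C)c1cccc(F)c1N1CCN(C(=O)[C@@H]2CN(C(C)C)C[C@H]2c2ccc(Cl)cc2)CC1`: 5.3 nM
- compound 2 `CC(C)[C@H](NC(=O)CCN(C)C)c1cccc(F)c1N1CCN(C(=O)[C@@H]2CN(C(C)C)C[C@H]2c2ccc(F)c(Cl)c2)CC1`: 260 nM
- compound 3 `Cc1ccc(N2CCN(C(=O)[C@@H]3CN(C4CCOCC4)C[C@H]3c3ccc(Cl)cc3)CC2)c([C@@H](NC(=O)[C@H](C)N)C(C)C)c1`: 1 nM

These three compounds were tested in an assay on HEK293 cells for displacement of a labelled ligand from Melanocortin receptor 4 (Homo sapiens); on this read-out lower numbers stand for stronger inhibition and higher numbers for weaker inhibition. Among them compound 2 gives the highest number, so it is the weakest binder of the set: compound 2 sits at 260 nM, while compound 1 at 5.3 nM and compound 3 at 1 nM both come in far lower.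

Compound 4 `CC(C)[C@H](NC(=O)CCN(C)C)c1cccc(F)c1N1CCN(C(=O)[C@@H]2CN(C(C)C)C[C@H]2c2cc(F)ccc2F)CC1` has not yet been measured. It comes from compound 2 by a single change: 2,5-difluorophenyl in place of 3-chloro-4-fluorophenyl on a saturated ring carbon.

Among the measured compounds shown here, only one measured step bears on this position. Going a 49-fold higher number from compound 1 to compound 2 (1.69 log units; beyond the scatter) shows that altering the substituents on this phenyl ring can shift binding strongly. Compound 4 returns neither to the 4-chlorophenyl of compound 1 nor keeps the pattern of compound 2, so the direction is uncertain. On balance, a modest move toward stronger binding is expected for compound 4, but with a wide margin, since a single step cannot fix the size.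

The estimate for compound 4 in this assay is 150 nM, within a range from 25 nM to 900 nM, which would mean an expected step of a 1.7-fold lower number from compound 2 to compound 4 (0.24 log units; within the scatter).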

Compound 4, inhibition constant: 2050 nM
Beside the measured number, compound 4's estimate is 14-fold (1.14 log units) below it, and the stated range ends below it.
By their numbers in this assay, from the lowest: compound 3; then compound 1; then compound 2; then compound 4.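

In this assay, 2,5-difluorophenyl in place of 3-chloro-4-fluorophenyl gives a 7.9-fold higher number from compound 2 to compound 4 (0.90 log units; beyond the scatter) and so does not recover any of the binding lost on leaving 4-chlorophenyl. Taken from the 4-chlorophenyl ring, the same position shows a 390-fold higher number from compound 1 to compound 4 (2.59 log units; beyond the scatter) in all, which makes 4-chlorophenyl the best of the three rings carried by compounds that otherwise match. The step from compound 2 to compound 4 also keeps the heavy-atom count unchanged, and neither group has hydrogen-bond donors or acceptors, so these counts alone do not set the binding here; the identity and placement of the halogens on the ring matter.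

On these data alone, it remains open how a plain phenyl ring, or one bearing a methoxy group or a nitrile, would fare at this position, and whether the same order of rings would hold on the core of compound 3. Nothing in the available data explains why these rings differ so widely.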